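The source may report more compounds than this note shows. Statements on the series, on what has been measured and on what is new or still open speak of the compounds shown alone.

Compound 1, `COc1cc2[nH]c([S+]([O-])Cc3nccc(OC)c3OC)nc2cc1OC(F)F`, gives 800 h in an ADME assay for pharmacokinetics, at pH 7.4; a higher number here means that the compound lasts longer, a lower number that the compound disappears faster.
Compound 2, `COc1cc2[nH]c([S+]([O-])Cc3nccc(OC)c3C)nc2cc1OC(F)F`, gives 11 h.
Compound 3, `COc1ccnc(C[S+]([O-])c2nc3cc(F)c(OC(F)F)cc3[nH]2)c1OC`, gives 150 h.

Compound 4, `COc1ccnc(C[S+]([O-])c2nc3cc(F)c(OC(F)F)cc3[nH]2)c1C`, has not yet been measured in this assay. It differs from compound 3 in one place: methyl in place of methoxy on an aromatic carbon. The same change is seen between compound 1 and compound 2, (methyl in place of methoxy on an aromatic carbon), and there it made a 73-fold lower number from compound 1 to compound 2 (1.86 log units; beyond the scatter). How the core of compound 1 differs from the core of compound 3 is not broken down here. Going by the values given here, a step of similar size is expected here, a 75-fold lower number from compound 3 to compound 4 (1.88 log units; beyond the scatter), because a 73-fold lower number from compound 1 to compound 2 (1.86 log units; beyond the scatter) is the only measured example of this change and it rests on a single pair. Compound 4 is therefore estimated to give about 2 h, expected between 0.7 h and 7 h.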

Compound 4, half-life: 4 h
The estimate for compound 4 lay 2.0-fold (0.30 log units) below the measured number; low and high end bracket the measured number.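

In this assay, methyl in place of methoxy again gives a large fall in the number (a 38-fold lower number from compound 3 to compound 4 (1.57 log units; beyond the scatter)). The change therefore carries over from the core of compound 1 to the core of compound 3, and the two steps match as closely as such measurements can show: the same change on two cores in this assay, a 73-fold lower number (1.86 log units; beyond the scatter) from compound 1 to compound 2 and a 38-fold lower number (1.57 log units; beyond the scatter) from compound 3 to compound 4, 1.9-fold (0.29 log units) apart, within the scatter of two such steps. Going by these compounds alone, this rests on only two pairs of compounds, so it does not show that the step would keep its size on other cores, nor does it explain why the number falls.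

The compounds shown leave open what other groups at this place would do, such as an ethoxy group, a chlorine atom or an amine. They also leave open how the step behaves on a core carrying a carboxylic acid.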